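Aryl swap on the ring amine nitrogen: expected potency

This account rests on a few compounds, and the source may have more. Where it says the series, first, only, none or still open, it means among the compounds named here.

Measured so far:
compound 1, `O=C(Nc1ccccc1Br)N[C@@H]1CCN(c2ccc(F)c(F)c2)C1`, in a functional assay for antagonist activity at transient receptor potential cation channel subfamily V member 1 (Rattus norvegicus), read by FLIPR (a lower number here means a less potent compound, a higher number a more potent compound, by a factor of ten per unit of this negative logarithm), gives 8.1
compound 2, `O=C(Nc1ccccc1Br)N[C@@H]1CCN(c2cccc(C(F)(F)F)n2)C1`, in this assay gives 7.2

Compound 1 holds the higher of the two numbers. Its nearest neighbour, compound 2, sits lower by a gap that is beyond the usual scatter of repeated measurements. Going by the values given here, no pair of measured compounds differs in only one place, so no single-change step is known within this set; the two values show only that the group on the amine nitrogen in a ring moves the number in this assay by more than the scatter.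

Compound 3, `Cc1ccc(N2CC[C@@H](NC(=O)Nc3ccccc3Br)C2)nc1`, has not yet been measured in this assay. Relative to compound 1 it differs as follows: 5-methylpyridin-2-yl in place of 3,4-difluorophenyl on an amine nitrogen in a ring.

Among the compounds with values here, with no directly comparable step on record, the expectation for compound 3 rests on the two values alone. The step from compound 1 to compound 3 is expected to be a number 0.50 log units lower from compound 1 to compound 3 (beyond the scatter), a moderate loss, since compound 2, which also carries a pyridin-2-yl on that nitrogen, gives 7.2. For compound 3 the estimated value in this assay is 7.6, within a range from 7 to 8.2.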

Compound 3, negative logarithm of the antagonist equilibrium constant: < 6.7
Compound 3 ended at the assay's limit (the forecaster's own chance of this, stated with the estimate: 5%); middle value at least 0.90 log units from the limit.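

In this assay, going by these compounds alone, 5-methylpyridin-2-yl in place of 3,4-difluorophenyl on the amine nitrogen in the ring gives a number at least 1.40 log units lower from compound 1 to compound 3 (beyond the scatter), the first single-change step on record at this position. Compound 3 stands at < 6.7, which is a limit of the assay and not a number: the limit of < 6.7 in this assay, at which 1 of the 3 values shown sits. Compound 2, which also has a pyridin-2-yl on that nitrogen, gives 7.2, a measured number. A pyridin-2-yl at this position therefore does not by itself put a compound at the limit.

Within the data shown here, the true value of compound 3 stays unknown, and its single step swaps the ring hetero atom, the two fluorines and the methyl together, so the share of each cannot be read. A plain phenyl, a methylphenyl or an unsubstituted pyridin-2-yl on the same nitrogen would separate these parts of the change.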